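Swapping a Ring for a Branched Chain in Compound 2

A few compounds are considered here, and "the series" means these few. Any claim that something is new, unique, unknown or untested is made for them only; others in the source may bear on it.

In a functional assay on SW1573 cells (Homo sapiens) for antiproliferative activity, read by sulforhodamine B assay, with a stated time of 48 h (on this read-out lower numbers stand for stronger inhibition of growth and higher numbers for weaker inhibition of growth), three compounds with a shared core have been measured. Compound 1 `CCC(C#CC(=O)OC)O/C=C/C(=O)OC` gives 540 nM, compound 2 `COC(=O)C#CC(O/C=C/C(=O)OC)C1CCCCC1` gives 2100 nM and compound 3 `COC(=O)C#CC(C[C@@H](C)CCC=C(C)C)O/C=C/C(=O)OC` gives 2200 nM. Compound 2 thus sits within the scatter of compound 3, and both numbers are higher than that of compound 1.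

Compound 4 `CCC(C)C(C#CC(=O)OC)O/C=C/C(=O)OC` has not yet been measured. It differs from compound 2 by a single change: sec-butyl in place of cyclohexyl on a saturated chain carbon bound to an oxygen on an unsaturated carbon and a triple-bonded carbon. Sec-butyl takes the place of cyclohexyl on a saturated chain carbon bound to an oxygen on an unsaturated carbon and a triple-bonded carbon.

Among the measured compounds shown here, the one measured step that swaps a group directly at this place is a 3.9-fold higher number from compound 1 to compound 2 (0.59 log units; beyond the scatter), a modest rise beyond the scatter that comes with cyclohexyl replacing ethyl. Sec-butyl has no ring, as ethyl has none, so part of that rise might be undone. Yet compound 3, which carries an open chain there, gives 2200 nM, so the absence of a ring does not ensure a low number. What is expected is a partial return toward lower numbers, a 1.9-fold lower number from compound 2 to compound 4 (0.28 log units; within the scatter), a step that may not clear the scatter. For compound 4 the estimated value is 1100 nM, with an expected range from 480 nM to 2500 nM.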

Compound 4, concentration for 50% growth inhibition: 910 nM
Beside the measured number, compound 4's estimate is 1.2-fold (0.08 log units) above it; low and high end bracket the measured number.
By their numbers in this assay, from the lowest: compounds 1 and 4 (each within the scatter of the next); then compounds 2 and 3 (each within the scatter of the next).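

In this assay the ring at this position can be given up with a gain: a 2.3-fold lower number from compound 2 to compound 4 (0.36 log units; beyond the scatter), a step that clears the usual scatter when sec-butyl takes the place of cyclohexyl on a saturated chain carbon bound to an oxygen on an unsaturated carbon and a triple-bonded carbon. The open branched chain also stays close to the small group, since sec-butyl where compound 1 carries ethyl gives a 1.7-fold higher number from compound 1 to compound 4 (0.23 log units; within the scatter), so this position accepts a larger group than ethyl without a clear loss, whereas the cyclohexyl of compound 2 does not stay that close, as a 3.9-fold higher number from compound 1 to compound 2 (0.59 log units; beyond the scatter) shows. Compound 3 keeps this from being a rule for all open chains, and no measurement here explains why cyclohexyl and sec-butyl part in this way.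

The compounds shown leave open whether the rise with cyclohexyl follows from the ring itself or simply from the larger group, a question that a cyclopropyl or cyclopentyl ring, or a straight propyl or hexyl chain, at this place could help to settle. They also say nothing about a group carrying an amine or a hydroxyl at this position.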